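A few compounds are considered here, and "the series" means these few. Any claim that something is new, unique, unknown or untested is made for them only; others in the source may bear on it.

Measured so far:
compound 1, `Cc1nn([C@H](C)c2ccc(Cl)cc2Cl)c2nc(N3CC[C@H](N4CCC[C@H]4C(N)=O)[C@H](C)C3)cnc12`, 170 nM
compound 2, `Cc1nn([C@H](C)c2ccc(Cl)cc2Cl)c2nc(N3CC[C@H](N4CCC[C@H]4CCS(C)(=O)=O)[C@H](C)C3)cnc12`, 104 nM
compound 3, `Cc1nn([C@H](C)c2ccc(Cl)cc2Cl)c2nc(N3CC[C@H](N4CCC[C@H]4CCC#N)[C@H](C)C3)cnc12`, 41 nM

All three were run in a functional assay on cells for antagonist activity at C-C chemokine receptor type 4 (Homo sapiens), read by fluorescence and calcium flux, with stated times of 2.5 s and 45 s; a lower number here means a stronger inhibitor, a higher number a weaker inhibitor. Compound 3 stands at the lowest number of the three, and both gaps to it lie beyond the scatter: a 2.5-fold lower number from compound 2 to compound 3 (0.40 log units; beyond the scatter) and a 4.1-fold lower number from compound 1 to compound 3 (0.62 log units; beyond the scatter). The step that compares compound 1 with compound 2 is smaller, a 1.6-fold lower number from compound 1 to compound 2 (0.21 log units; within the scatter), and within the scatter.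

Compound 4 is `Cc1nn([C@H](C)c2ccc(Cl)cc2Cl)c2nc(N3CC[C@H](N4CCC[C@H]4CCC(N)=O)[C@H](C)C3)cnc12`. It differs from compound 3 in one place: carbamoyl in place of cyano on a saturated chain carbon, two bonds along the chain from a saturated ring carbon. Among the compounds with values here, two measured steps bear on this. In one, carbamoyl left and 2-cyanoethyl entered on the saturated ring carbon, a 4.1-fold lower number from compound 1 to compound 3 (0.62 log units; beyond the scatter); in the other, methylsulfonyl gave way to cyano on the saturated chain carbon, a 2.5-fold lower number from compound 2 to compound 3 (0.40 log units; beyond the scatter). In both, the arrival of cyano went with a lower number; here cyano leaves and carbamoyl enters, so a modest rise in the number is expected, as a 2.4-fold higher number from compound 3 to compound 4 (0.39 log units; beyond the scatter). Compound 4 is therefore estimated at 100 nM, with a range from 40 nM to 250 nM.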

Compound 4, half-maximal inhibitory concentration: 37 nM
Estimate against measurement, compound 4: 2.7-fold (0.43 log units) above; measured number outside the range, below it.
By their numbers in this assay, from the lowest: compounds 4 and 3 (each within the scatter of the next); then compounds 2 and 1 (each within the scatter of the next).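

In this assay, carbamoyl in place of cyano on the saturated chain carbon, two bonds along the chain from a saturated ring carbon, gives no separation (a 1.1-fold lower number from compound 3 to compound 4 (0.04 log units; within the scatter)), so the nitrile is not required at this place for the lower numbers seen here. The carbamoyl group itself is therefore not what sets compound 1 apart, since 2-carbamoylethyl in its place on the saturated ring carbon gives a clear drop (a 4.6-fold lower number from compound 1 to compound 4 (0.66 log units; beyond the scatter)). At the chain position, carbamoyl also compares well with methylsulfonyl (a 2.8-fold lower number from compound 2 to compound 4 (0.45 log units; beyond the scatter)), a gap beyond the scatter.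

No measurement shown explains why the nitrile and the carbamoyl read alike here. Still open, as far as these compounds go, is how a carboxylic acid or an amine at this chain carbon would read, and how carbamoylmethyl or a longer chain ending in carbamoyl would compare.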